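Swapping methyl for fluoro on a quite different core

A few compounds are considered here, and "the series" means these few. Any claim that something is new, unique, unknown or untested is made for them only; others in the source may bear on it.

Of the compounds shown here, three of one series have been tested in a functional assay on MCF7 cells (Homo sapiens) for cytotoxicity, read by WST assay, with a stated time of 72 h; a lower number here means a stronger inhibitor, a higher number a weaker inhibitor. Compound 1 `O=C1Nc2c(ccc(F)c2F)C1(c1ccc(O)cc1)c1ccc(F)cc1` gives 2.6 nM, and compound 2 `Cc1ccc(C2(c3ccc(O)cc3)C(=O)Nc3c2ccc(F)c3F)cc1` gives 1.7 nM. Compound 3 `Cc1cc(C)c2c(c1)C(c1ccc(O)cc1)(C1CCCCCC1)C(=O)N2` is reported only as a limit, and in this assay compound 3 gives > 1000 nM, which is the limit of > 1000 nM in this assay, at which 1 of the 3 values shown sits, and not a number.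

Compounds 2 and 1 differ in one place, (fluoro in place of methyl on an aromatic carbon), and this change gave a 1.5-fold higher number from compound 2 to compound 1 (0.18 log units; within the scatter). Compound 4 `Cc1cc(F)cc2c1NC(=O)C2(c1ccc(O)cc1)C1CCCCCC1` has not yet been measured; it arises from compound 3 by fluoro in place of methyl on an aromatic carbon. The two changes are the same kind of change, but not the same: in the pair of compounds 2 and 1 the place is para to a large group, whereas in the pair of compounds 3 and 4 it is meta to a fused ring, meta to a methyl group and para to a fused ring. How the core of compound 3 differs from the core of compound 2 is not broken down here.

For compound 4 the step in this assay is expected to be a step that the limit leaves unreadable from compound 3 to compound 4, because compound 3 already sits at the limit of > 1000 nM in this assay, at which 1 of the 3 values shown sits, and the earlier change stayed within the scatter. Compound 4 is therefore estimated at 1500 nM, between 500 nM and 5000 nM.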

Compound 4, half-maximal inhibitory concentration: > 1000 nM
Compound 4: a limit, no number; the forecaster's own chance of this, stated with the estimate: 75%; the middle value does not contradict the limit.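

In this assay compound 4 gives > 1000 nM, which is a limit and not a number. Compound 3 is also reported only as a limit, so no size can be read for the step between these two compounds. The compounds shown leave open how much fluoro in place of methyl changes the activity on the core of compound 3.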